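Swapping the anilino ring on a shared core

The source may hold more compounds than are shown below. What is called first, only, known or untested is meant among the compounds shown, and "the series" means these compounds.

Compound 1, `O=C(CSc1nc(Nc2ccccc2)c2ccccc2n1)Nc1ccc(F)cc1`: in a functional assay on MGC-803 cells (Homo sapiens) for inhibition, read by MTT assay, with a stated time of 72 h (a higher number here means a weaker inhibitor, a lower number a stronger inhibitor), compound 1 gives only a limit, > 50000 nM, not a number.
Compound 2, `C=CC(=O)Nc1cccc(NC(=O)CSc2nc(Nc3ccccc3Br)c3ccccc3n2)c1`: in this assay compound 2 gives 12800 nM.

Within the data shown here, compound 2 thus stands as the only compound with a measured number. Compound 1 sits at the limit of > 50000 nM in this assay, at which 1 of the 2 values shown sits. Among the measured compounds shown here, no pair of measured compounds differs in just one place, so no measured step exists to guide the next change.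

Compound 3, `C=CC(=O)Nc1cccc(NC(=O)CSc2nc(Nc3ccc(C(F)(F)F)cc3)c3ccccc3n2)c1`, differs from compound 2 in one place: 4-(trifluoromethyl)phenyl in place of 2-bromophenyl on a nitrogen on an aromatic ring. For the measured compounds named here, with no measured step of this kind to compare against, the expectation in this assay is a step no larger than the usual scatter, in no particular direction. The expected step is no change at the digits printed from compound 2 to compound 3 (within the scatter). Compound 3 is accordingly estimated at 12800 nM, within a range from 4000 nM to 40000 nM.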

Compound 3, half-maximal inhibitory concentration: 12100 nM
Compound 3: the middle estimate sits 1.1-fold (0.02 log units) above what was measured; measured number inside the range.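

Among these compounds, putting 4-(trifluoromethyl)phenyl in place of 2-bromophenyl on a nitrogen on an aromatic ring gives the first measured step at this position: a 1.1-fold lower number from compound 2 to compound 3 (0.02 log units; within the scatter). The two groups differ in what the ring carries and where, and the entering group has 10 heavy atoms against 7, yet this one swap does not separate compound 2 from compound 3 in this assay. Nothing measured here explains why these two readings lie so close.

Compound 1 gives > 50000 nM, which is a limit and not a number, and it differs from the other two compounds in more than one place. On these data alone, whether a carboxylic acid on this ring, or a morpholine in place of it, would give a step beyond the scatter in this assay remains open.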